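The source may hold more compounds than are shown below. What is called first, only, known or untested is meant among the compounds shown, and "the series" means these compounds.

Working notes on the series. The compounds share one core and differ in the group on the oxime-type oxygen: compound 1 is `C#CCc1c(Cl)cc(N/C=N/O)cc1Cl`, compound 2 is `C#CCc1c(Cl)cc(N/C=N/OC)cc1Cl` and compound 3 is `C#CCc1c(Cl)cc(N/C=N/OCOCC)cc1Cl`. In a physicochemical assay for lipophilicity, measured as octanol-water partition (a lower number here means a more polar compound, a higher number a more lipophilic compound), compound 1 gives 2.8, compound 2 gives 3.3 and compound 3 gives 3.5. Compound 3 and compound 2 form the upper pair of these three numbers, and compound 1 stands apart from both.

Next is compound 4, `C#CCc1c(Cl)cc(N/C=N/OC/C=C/Cl)cc1Cl`, which carries 2-chloroethenyl in place of ethoxy on a saturated chain carbon bound to an oxygen.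

Among the compounds with values here, three measured steps bear on this change. The closest is at the same place, a number 0.20 log units higher from compound 2 to compound 3 (within the scatter), where ethoxy replaces hydrogen. Further back, on the oxygen itself, stand a number 0.50 log units higher from compound 1 to compound 2 (beyond the scatter) and a number 0.70 log units higher from compound 1 to compound 3 (beyond the scatter). Within the data shown here, no measured compound carries 2-chloroethenyl, so the new group has no direct precedent here and the uncertainty stays wide. A modest rise in this assay is expected, similar in size to the step from hydrogen to methyl on the oxygen and larger than the step at the same place.

The expected change is a number 0.50 log units higher from compound 3 to compound 4 (beyond the scatter).

For compound 4 the estimated value is 4, with an expected range from 3.5 to 4.5.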

Compound 4, partition coefficient: 3.9
The estimate for compound 4 lay 0.10 log units above the measured number; the measured number falls inside the stated range.
By their numbers in this assay, from the lowest: compound 1; then compounds 2 and 3 (each within the scatter of the next); then compound 4.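

Within the data shown here, at the saturated chain carbon bound to an oxygen, the only earlier step was a number 0.20 log units higher from compound 2 to compound 3 (within the scatter), and 2-chloroethenyl now gives the first step at this place beyond the scatter in this assay, with a number 0.40 log units higher from compound 3 to compound 4 (beyond the scatter) against ethoxy and a number 0.60 log units higher from compound 2 to compound 4 (beyond the scatter) against hydrogen. Ethoxy and 2-chloroethenyl hold the same number of heavy atoms, so the step from one to the other comes with no change in that count, while the change read on the oxygen itself, from hydrogen to 3-chloroprop-2-en-1-yl, is the only large step in the series, a number 1.10 log units higher from compound 1 to compound 4 (beyond the scatter). Nothing among the data shown accounts for the size of these steps.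

The compounds shown leave open whether this step belongs to the chlorine, to the double bond or to the two together, a question that plain ethenyl and saturated 2-chloroethyl at the same place would separate. They also leave open how far the number would fall with a primary amine or a carboxylic acid on this carbon, and whether a longer chain such as butyl would carry it further up.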